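Second methoxy on the aryl ring of compound 2

The source may hold more compounds than are shown below. What is called first, only, known or untested is meant among the compounds shown, and "the series" means these compounds.

Compound 2 `COc1ccc(C2CC(c3ccc(OCc4cn(Cc5ccc([N+](=O)[O-])cc5)nn4)cc3)=NN2C(C)=O)cc1` gives 26% in a functional assay on A549 cells (Homo sapiens) for inhibition, read by sulforhodamine B assay, tested at 10 uM (a lower number here means less inhibition of growth, a higher number more inhibition of growth at the concentration tested), the second highest of the three measured numbers. Compound 1 `CC(=O)N1N=C(c2ccc(OCc3cn(Cc4ccc([N+](=O)[O-])cc4)nn3)cc2)CC1c1ccccc1` gives 15% and stands nearest; compound 3 `COc1cc(C2CC(c3cccc4ccccc34)=NN2C(C)=O)ccc1OCc1cn(Cc2ccc([N+](=O)[O-])cc2)nn1` gives 89% and stands furthest. Compound 4 `COc1ccc(C2CC(c3ccc(OCc4cn(Cc5ccc([N+](=O)[O-])cc5)nn4)cc3)=NN2C(C)=O)cc1OC` differs from compound 2 by methoxy in place of hydrogen on an aromatic carbon. Among the compounds with values here, the one measured step of the same kind, methoxy in place of hydrogen on an aromatic carbon, is a number 11 percentage points higher from compound 1 to compound 2 (beyond the scatter), a modest rise beyond the scatter. Within the data shown here, no single-place step links compound 3 to compound 2, so its number bears no further on this change. A rise of similar size is therefore expected, a number 10 percentage points higher from compound 2 to compound 4 (within the scatter). Compound 4 is estimated at 36%, with a range of 18% to 55%.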

Compound 4, percent growth inhibition at one concentration: 11%
Compound 4: the middle estimate sits 25 percentage points above what was measured, outside the stated range (below it).
By their numbers in this assay, from the lowest: compounds 4 and 1 (each within the scatter of the next); then compound 2; then compound 3.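

In this assay, the same change does not carry over within this aryl ring: after a number 11 percentage points higher from compound 1 to compound 2 (beyond the scatter), a second methoxy, ortho to the first, gives a number 15 percentage points lower from compound 2 to compound 4 (beyond the scatter). With a number 4 percentage points lower from compound 1 to compound 4 (within the scatter), 3,4-dimethoxyphenyl does not separate from phenyl, so the rise seen with 4-methoxyphenyl is absent here. No available evidence accounts for this reversal.

Still open, as far as these compounds go, is whether a hydroxy group or a chlorine atom at this place would give a number like that of compound 4. Also open, from the compounds shown here alone, is what a methoxy here gives without the 4-methoxy group.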